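The compounds below may be only part of what the source reports. "The series", "measured", "known", "first", "only" and "open" are said of these compounds alone.

Two pairs of related compounds are compared in a functional assay on MCF7 cells (Homo sapiens) for cytotoxicity, read by MTT assay, with a stated time of 6 days; a lower number here means that less compound is needed, a higher number that more compound is needed for the effect. Compound 1 `O=c1cc(-c2ccc([N+](=O)[O-])cc2)oc2cc(O)ccc12` carries a single hydroxy group on its core. In this assay compound 1 reaches only a limit of the assay, > 25 ug/mL. Compound 2 `O=c1cc(-c2ccc([N+](=O)[O-])cc2)oc2c(O)c(O)ccc12` differs from compound 1 in one place: hydroxy in place of hydrogen on an aromatic carbon. In this assay compound 2 gives 4.69 ug/mL. That change produced an at least 5.3-fold lower number from compound 1 to compound 2 (0.72 log units; beyond the scatter), a step whose lower bound is set by the limit of > 25 ug/mL in this assay, at which 2 of the 3 values shown sit.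

Compound 3 `COc1cc(-c2cc(=O)c3ccc(O)cc3o2)cc(OC)c1OC` has a different core from compound 1; the difference between the two cores is not broken down here. In this assay compound 3 also sits at a limit of the assay, > 25 ug/mL. Compound 4 `COc1cc(-c2cc(=O)c3ccc(O)c(O)c3o2)cc(OC)c1OC`, not yet measured, is built from compound 3 by the same change: hydroxy in place of hydrogen on an aromatic carbon. The surroundings of the place are described in the same words for both pairs, so the change is the same.

Because the earlier step was an at least 5.3-fold lower number from compound 1 to compound 2 (0.72 log units; beyond the scatter), a drop of similar size is expected from compound 3 to compound 4. The number for compound 1 is only a limit, so the full size of that first step is not known, and the expectation for compound 4 therefore carries wide uncertainty. For compound 4 the expected value is 6 ug/mL, between 2 ug/mL and 25 ug/mL. The step this implies is expected to be an at least 4.1-fold lower number from compound 3 to compound 4 (0.61 log units; beyond the scatter).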

Compound 4, concentration for half-maximal effect: 1.11 ug/mL
Compound 4: middle estimate off by 5.4-fold (0.73 log units), on the high side; measured number outside the range, below it.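

In this assay, the same hydroxy group on the second core gives an at least 22-fold lower number from compound 3 to compound 4 (1.35 log units; beyond the scatter), so the change that lowered the number on the core of compound 1 also lowers it on the core of compound 3, and both steps lie beyond the scatter. This shows that the direction of the change carried over between these two cores, but it does not show that the step has the same size on both, and the two steps can be set side by side only with that caution: the same change on two cores in this assay, an at least 5.3-fold lower number (0.72 log units; beyond the scatter) from compound 1 to compound 2 and an at least 22-fold lower number (1.35 log units; beyond the scatter) from compound 3 to compound 4; the limit leaves it open whether they differ. Each step starts from a limit rather than a true number, so neither full size is known, and two pairs make no rule for a further core: the limit of > 25 ug/mL in this assay, at which 2 of the 4 values shown sit.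

The compounds shown leave open whether another group at this place on the ring, such as an amine or a carboxylic acid, would lower the number as the hydroxy group does. They also leave open whether a hydroxy group would have the same effect at a place on the ring that is not ortho to a hydroxy group.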